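Methoxy in place of methyl: from compound 2 to compound 4

The compounds below may be only part of what the source reports. "The series", "measured", "known", "first", "only" and "open" are said of these compounds alone.

Measured compounds:
compound 1 `Cc1ccc2nc(Nc3nc(Nc4ccc(S(N)(=O)=O)cc4)ncc3F)sc2c1`: 4960 nM
compound 2 `Cc1ccc2nc(Nc3nc(Nc4ccc(S(N)(=O)=O)cc4)ncc3C)sc2c1`: 2710 nM
compound 3 `Cc1cnc(Nc2ccc(Cl)cc2)nc1Nc1nc2ccccc2s1`: > 50000 nM

Of the compounds shown here, three have been tested in a functional assay on PC-3 cells (Homo sapiens) for antiproliferative activity, read by MTT assay, with a stated time of 48 h; on this read-out higher numbers stand for weaker inhibition and lower numbers for stronger inhibition. Compound 1 gives 4960 nM and compound 2 gives 2710 nM. For compound 3 the assay reports only a limit, > 50000 nM, which is not a number (the limit of > 50000 nM in this assay, at which 1 of the 3 values shown sits). Among the two numbers compound 2 holds the lowest, with compound 1 as its nearest neighbour; the single measured step, a 1.8-fold lower number from compound 1 to compound 2 (0.26 log units; within the scatter), lies within the scatter, so no order between compound 1 and compound 2 can be stated.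

Compound 4 `COc1ccc2nc(Nc3nc(Nc4ccc(S(N)(=O)=O)cc4)ncc3C)sc2c1` differs from compound 2 in one place: methoxy in place of methyl on an aromatic carbon. For the measured compounds named here, the only measured step exchanges fluoro for methyl at another place and says nothing about the exchange of methyl for methoxy, so no step bears directly on this change. Going by the values given here, with no measured step to draw on, the step from compound 2 to compound 4 is expected to be a 1.1-fold lower number from compound 2 to compound 4 (0.04 log units; within the scatter), not beyond the scatter in either direction. Compound 4 is therefore estimated to give 2500 nM in this assay, with a range from 900 nM to 7000 nM.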

Compound 4, half-maximal inhibitory concentration: > 50000 nM
Compound 4 was reported as a limit; the forecaster's own chance of this, stated with the estimate: 3%; middle value at least 20-fold (1.30 log units) away from the limit.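

In this assay, methoxy in place of methyl on this aromatic carbon gives an at least 18-fold higher number from compound 2 to compound 4 (1.26 log units; beyond the scatter), so this position of the shared core responds strongly to a small exchange, which adds one heavy atom and one hydrogen-bond acceptor. The only earlier step, a 1.8-fold lower number from compound 1 to compound 2 (0.26 log units; within the scatter), lay at another place and showed no change that could be told from the scatter, so this is the first step among these compounds to separate two of them clearly. The reading of compound 4 is a limit and not a number, so the step gives only a lower bound on the loss of inhibition: the limit of > 50000 nM in this assay, at which 2 of the 4 values shown sit.

What an ethyl group, which carries no oxygen, or a hydroxyl group, which carries no added carbon, would give at this position remains open, so the compounds shown cannot tell whether the oxygen or the larger group goes with the loss. From the compounds shown here alone, it also remains open whether methoxy at this position would have the same effect with fluoro in place of the methyl at the other place, as in compound 1.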